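This account rests on a few compounds, and the source may have more. Where it says the series, first, only, none or still open, it means among the compounds named here.

Measured so far:
compound 1 `CCCCc1coc([C@@H](CC)Nc2c(Nc3cccc(C(=O)N(C)C)c3O)c(=O)c2=O)c1`: 34 nM
compound 2 `CCC(CC)c1coc([C@@H](CC)Nc2c(Nc3cccc(C(=O)N(C)C)c3O)c(=O)c2=O)c1`: 30 nM

In an assay on CHO cells for displacement of a labelled ligand from C-X-C chemokine receptor type 1 (Homo sapiens) (a higher number here means a weaker inhibitor, a lower number a stronger inhibitor), compound 1 gives 34 nM and compound 2 gives 30 nM. Compound 2 stands level with compound 1, since the step of a 1.1-fold lower number from compound 1 to compound 2 (0.05 log units; within the scatter) is within the scatter. Compound 3 `CC[C@@H](Nc1c(Nc2cccc(C(=O)N(C)C)c2O)c(=O)c1=O)c1cc(C2CCCCC2)co1` is not yet measured; it differs from compound 2 by cyclohexyl in place of pentan-3-yl on an aromatic carbon. Among the compounds with values here, the only measured step, a 1.1-fold lower number from compound 1 to compound 2 (0.05 log units; within the scatter), exchanged one chain for another on the same aromatic carbon and changed little. A ring entering there is a new kind of change, but nothing measured points to a shift, so the expected step is no change at the digits printed from compound 2 to compound 3 (within the scatter), none beyond the scatter. For compound 3 the expected value is 30 nM, with a range from 12 nM to 75 nM.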

Compound 3, inhibition constant: 283 nM
Compound 3: middle estimate off by 9.4-fold (0.97 log units), on the low side; measured number outside the range, above it.
By their numbers in this assay, from the lowest: compounds 2 and 1 (each within the scatter of the next); then compound 3.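

In this assay, placing cyclohexyl on this aromatic carbon gives a 9.4-fold higher number from compound 2 to compound 3 (0.97 log units; beyond the scatter) when it replaces pentan-3-yl and an 8.3-fold higher number from compound 1 to compound 3 (0.92 log units; beyond the scatter) when it replaces butyl as the comparison. The position therefore does not treat every carbon-only group alike: the two open chains stand level, while the group carrying a six-membered ring gives a clearly weaker inhibitor. The compounds shown leave open whether the ring itself or the added carbon matters, which a cyclopentyl or hexyl group could help separate. Nothing available explains this loss.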